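A few compounds are considered here, and "the series" means these few. Any claim that something is new, unique, unknown or untested is made for them only; others in the source may bear on it.

Measured so far in an assay on HEK293 cells for positive allosteric modulation of metabotropic glutamate receptor 3 (Rattus norvegicus), read by thallium flux, with a stated time of 2.5 min; a higher number here means a larger maximal response, a lower number a smaller maximal response:
compound 1 `Cc1c(OCCCCOc2ccc(C(=O)O)cc2)ccc(C(=O)CC2CCCC2)c1O`: 26.7%
compound 2 `Cc1cc(C(=O)O)ccc1OCCCCOc1ccc(C(=O)CC2CCCC2)c(O)c1C`: 28.4%

Of the two numbers, compound 2 has the nominally higher one, but compound 1 gives 26.7% and the step of a number 1.7 percentage points higher from compound 1 to compound 2 (within the scatter) lies within the scatter. Compound 3 `Cc1c(OCCCCOc2ccc(F)c(C(=O)O)c2)ccc(C(=O)CC2CCCC2)c1O` differs from compound 2 by 3-carboxy-4-fluorophenyl in place of 4-carboxy-2-methylphenyl on an oxygen on a saturated carbon. Within the data shown here, the only measured step concerns a methyl on an aromatic carbon and does not bear on this exchange at the carboxyphenyl end; no measured pair addresses it. The expected step of a number 1.4 percentage points lower from compound 2 to compound 3 (within the scatter) is therefore essentially none beyond the scatter, with wide uncertainty. Compound 3 is estimated at 27%, with a range from 14% to 42%.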

Compound 3, largest response reached (reported as percent of maximum), in percent of the reference or control that the assay uses: 98.4%
The estimate for compound 3 lay 71.4 percentage points below the measured number, and the stated range ends below it.
By their numbers in this assay, from the lowest: compounds 1 and 2 (each within the scatter of the next); then compound 3.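

In this assay the maximal response depends strongly on the aryl group on the oxygen on a saturated carbon: 3-carboxy-4-fluorophenyl in place of 4-carboxy-2-methylphenyl gives a number 70 percentage points higher from compound 2 to compound 3 (beyond the scatter), and in place of 4-carboxyphenyl it gives a number 71.7 percentage points higher from compound 1 to compound 3 (beyond the scatter). The methyl exchange had shown no change beyond the scatter, so this is the first large step in the series. No measurement shown accounts for the gain.

Still open, as far as these compounds go, is whether the fluorine, the move from 4-carboxy to 3-carboxy, or both together carry the step. Plain 3-carboxyphenyl, or chlorine in place of the fluorine, would bear on this.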